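Compound 4: imidazolyl in place of acetamido on the shared core

The source may hold more compounds than are shown below. What is called first, only, known or untested is meant among the compounds shown, and "the series" means these compounds.

Compound 1 `CCCCN(c1nc2c(NC(C)=O)cccc2o1)[C@H](C)c1ccc(-c2ccccc2-c2nnn[nH]2)cc1` stands second highest of three numbers in an ADME assay on the whole organism (Macaca fascicularis) for metabolic stability, read by LC-MS, using cassette dosing, at a dose of 1 mg/kg by the oral route (a lower number here means that the compound disappears faster, a higher number that the compound lasts longer), where compound 1 gives 2.2 h. Its nearest neighbour is compound 2 `CCCCN(c1nc2c(C(=O)O)cccc2o1)[C@H](C)c1ccc(-c2cc(Cl)ccc2-c2nc(=O)o[nH]2)cc1`, which gives 2 h in this assay, a difference within the scatter. Furthest is compound 3 `CCCCN(c1nc2c(C(=O)O)cccc2o1)[C@H](C)c1ccc(-c2ccccc2-c2nnn[nH]2)cc1`, which gives 3.7 h; the step of a 1.7-fold higher number from compound 1 to compound 3 (0.23 log units; within the scatter) also lies within the scatter, so the three numbers cannot be ordered.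

Compound 4 `CCCCN(c1nc2c(-c3nccn3C)cccc2o1)[C@H](C)c1ccc(-c2ccccc2-c2nnn[nH]2)cc1` is not yet measured. It differs from compound 1 in one place: 1-methyl-1H-imidazol-2-yl in place of acetamido on an aromatic carbon.

For the measured compounds named here, only the step from compound 1 to compound 3 bears on this change, since it replaces the same acetamido group at the same place on the core; that step was a 1.7-fold higher number from compound 1 to compound 3 (0.23 log units; within the scatter), within the scatter. Going by the values given here, compound 2 differs from compound 1 in more than one place and gives no separable step. There is therefore no ground to expect a step beyond the scatter in this assay for compound 4 in either direction; the step is estimated as a 1.0-fold higher number from compound 1 to compound 4 (0.02 log units; within the scatter). Compound 4 is expected to give 2.3 h in this assay, within the range 1.1 h to 4.6 h.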

Compound 4, half-life: 3.9 h
Estimate against measurement, compound 4: 1.7-fold (0.23 log units) below, within the range that was stated.
By their numbers in this assay, from the lowest: compounds 2, 1, 3 and 4 (each within the scatter of the next).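

In this assay, this aromatic carbon of the shared core now also carries a ring, 1-methyl-1H-imidazol-2-yl, and the step from the open acetamido group is a 1.8-fold higher number from compound 1 to compound 4 (0.25 log units; within the scatter). Against carboxy at the same place the step is a 1.1-fold higher number from compound 3 to compound 4 (0.02 log units; within the scatter), so acetamido, carboxy and 1-methyl-1H-imidazol-2-yl cannot be told apart here, even though the entering ring has no hydrogen-bond donor and more heavy atoms than acetamido. No measured finding bears on these numbers.

Still open, going by these compounds, is whether a primary amine, a methoxy group or a longer chain on this aromatic carbon would give a step beyond the scatter. Also open, on these data alone, is whether 1-methyl-1H-imidazol-2-yl would read the same with the other end of the molecule as it stands in compound 2.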